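Carboxy in place of tetrazolyl on compound 1

This account rests on a few compounds, and the source may have more. Where it says the series, first, only, none or still open, it means among the compounds named here.

Measured so far in a functional assay on HCT-116 cells (Homo sapiens) for antiproliferative activity, read by CellTiter-Glo, with a stated time of 72 h, in the presence of a further agent that is not named here; on this read-out lower numbers stand for an effect already at smaller amounts and higher numbers for an effect only at larger amounts of compound:
- compound 1 `Clc1ccc(Oc2cncc3sc(-c4nn[nH]n4)cc23)cc1` reads > 10000 nM (a limit)
- compound 2 `Cc1ccc(Oc2cncc3sc(-c4nn[nH]n4)cc23)cc1` reads > 10000 nM (a limit)

Compound 1 has no number in this assay and stands only at a limit. Among the measured compounds shown here, the series so far rests on the limit of > 10000 nM in this assay, at which 2 of the 2 values shown sit, and offers no measured potency. Compound 3 `O=C(O)c1cc2c(Oc3ccc(Cl)cc3)cncc2s1` carries carboxy in place of 2H-tetrazol-5-yl on an aromatic carbon next to the ring sulfur carboxy in place of 2H-tetrazol-5-yl on an aromatic carbon and otherwise keeps the core of compound 1.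

For the measured compounds named here, the single measured step that the two limits leave unreadable from compound 1 to compound 2 is methyl in place of chloro on an aromatic carbon. Going by the values given here, it gives no size to carry over, and no measured step touches this exchange. The expectation therefore rests on compound 1, whose reading of > 10000 nM is a limit, so no readable change is expected in this assay and another limit is the likelier outcome. The expected step is a step that the limit leaves unreadable from compound 1 to compound 3 with no direction that the data can support. Compound 3 is estimated at 20000 nM with an expected range from 5000 nM to 60000 nM in this working estimate.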

Compound 3, half-maximal effective concentration: > 10000 nM
Compound 3: no number, only a limit; the forecaster's own chance of this, stated with the estimate: 75%; the middle value lies beyond the limit too.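

Compound 1 and compound 3 both stand only at a limit in this assay, so the step between them cannot be read, and the series rests on a single reading: the limit of > 10000 nM in this assay, at which 3 of the 3 values shown sit.

The compounds shown leave open whether carboxy and 2H-tetrazol-5-yl differ at all in this assay, and which change to the shared core would give a measured potency.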